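Benzoyl in place of benzyloxycarbonyl in the hydroxamic acid series

This account rests on a few compounds, and the source may have more. Where it says the series, first, only, none or still open, it means among the compounds named here.

Among the compounds with values here, in a functional assay on K562 cells (Homo sapiens) for inhibition, read by CCK-8 assay, with a stated time of 48 h (a higher number here means a weaker inhibitor of growth, a lower number a stronger inhibitor of growth), compound 1 (`O=C(CCCSC[C@H](NC(=O)OCc1ccccc1)C(=O)Nc1ccccc1)NO`) gives 1700 nM and compound 2 (`O=C(CCCSC[C@H](NC(=O)OCc1ccccc1)C(=O)Nc1cccc2ccccc12)NO`) gives 2000 nM, so compound 1 stands level with the only other measured compound, within the scatter. Compound 3 (`O=C(CCCSC[C@H](NC(=O)c1ccccc1)C(=O)Nc1ccccc1)NO`) has phenyl in place of benzyloxy on a carbonyl carbon. Within the data shown here, the one measured step, a 1.2-fold higher number from compound 1 to compound 2 (0.07 log units; within the scatter), concerns a different place, an amide-type nitrogen, so it bears only indirectly. Among the measured compounds shown here, no measured step tests this change, and no shift beyond the scatter is expected in this assay. The expected step is a 1.2-fold higher number from compound 1 to compound 3 (0.07 log units; within the scatter). For compound 3 the estimate is 2000 nM, with an expected range of 800 nM to 5000 nM.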

Compound 3, concentration for 50% growth inhibition: 1400 nM
The estimate for compound 3 lay 1.4-fold (0.15 log units) above the measured number, within the range that was stated.
By their numbers in this assay, from the lowest: compounds 3, 1 and 2 (each within the scatter of the next).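

In this assay phenyl in place of benzyloxy on a carbonyl carbon gives a 1.2-fold lower number from compound 1 to compound 3 (0.08 log units; within the scatter) and thus shows that this position accepts benzoyl as well as benzyloxycarbonyl with no change beyond the scatter. Within the data shown here, the earlier step concerned only the amide-type nitrogen, so this is the first reading at this carbonyl carbon. No measurement on the compounds shown offers an explanation for this result. Still open, on these data alone, is whether acetyl or an acyl group carrying an amine or a carboxylic acid holds this level. Also open, as far as these compounds go, is how benzoyl behaves with naphthalen-1-yl on the amide-type nitrogen.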